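Diethylamino in place of isopropylamino on a thiophene analogue

The source may hold more compounds than are shown below. What is called first, only, known or untested is meant among the compounds shown, and "the series" means these compounds.

Three compounds were measured in an assay on membranes from HeLa cells for displacement of a labelled ligand from adenosine receptor A3 (Homo sapiens), read by scintillation counting, with a stated time of 180 min, tested at 1 uM; on this read-out higher numbers stand for more inhibition at the one concentration tested (going by the name of the read-out) and lower numbers for less inhibition. Compound 1 `CC1=C(C(=O)NC(C)C)C(c2ccoc2)NC(=O)N1` gives 3%. Compound 2 `CCN(CC)C(=O)C1=C(C)NC(=O)NC1c1ccoc1` differs from compound 1 by diethylamino in place of isopropylamino on a carbonyl carbon. In this assay compound 2 gives 37%, so that a number 34 percentage points higher from compound 1 to compound 2 (beyond the scatter). Compound 3 `CC1=C(C(=O)NC(C)C)C(c2ccsc2)NC(=O)N1` differs from compound 1 by thiophen-3-yl in place of furan-3-yl on a saturated ring carbon. In this assay compound 3 gives 1%, so that a number 2 percentage points lower from compound 1 to compound 3 (within the scatter); compound 3 and compound 1 therefore show numbers of the same order.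

Compound 4 `CCN(CC)C(=O)C1=C(C)NC(=O)NC1c1ccsc1` has not been measured in this assay. It differs from compound 3 by diethylamino in place of isopropylamino on a carbonyl carbon, the same change that leads from compound 1 to compound 2, and it occurs twice among the compounds shown. The core of compound 3 and the core of compound 1 differ as described above, and the two places of the change are described in the same words.

On the one earlier occurrence, compound 4 is expected to show a number 32 percentage points higher from compound 3 to compound 4 (beyond the scatter), resting on the step of a number 34 percentage points higher from compound 1 to compound 2 (beyond the scatter) and on the value that compound 3 gives, 1%. Compound 4 is estimated at 33%, between 12% and 54%.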

Compound 4, a percentage reported as inhibition, at one concentration (the size of the read-out at that concentration, not a potency): 35%
Compound 4: the middle estimate sits 2 percentage points below what was measured; the measured number falls inside the stated range.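

In this assay, diethylamino in place of isopropylamino gives a number 34 percentage points higher from compound 3 to compound 4 (beyond the scatter), so the step seen with furan-3-yl carries over to the thiophen-3-yl compounds at the same size: the same change on two cores in this assay, a number 34 percentage points higher (beyond the scatter) from compound 1 to compound 2 and a number 34 percentage points higher (beyond the scatter) from compound 3 to compound 4, 0 percentage points apart, within the scatter of two such steps. Read the other way, thiophen-3-yl in place of furan-3-yl gives a number 2 percentage points lower from compound 2 to compound 4 (within the scatter), so that ring exchange does not separate the compounds on either amino group: the same change on two cores in this assay, a number 2 percentage points lower (within the scatter) from compound 1 to compound 3 and a number 2 percentage points lower (within the scatter) from compound 2 to compound 4, 0 percentage points apart, within the scatter of two such steps. This shows the two changes behaving independently within these four compounds only; it does not show that the step would hold on a core changed in any other place, and a percentage at one concentration is not a potency.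

Diethylamino differs from isopropylamino both in its heavy atoms and in its hydrogen-bond donors, and the compounds shown do not tell these two differences apart. On these data alone, what dimethylamino or a longer chain such as dipropylamino would give on the same carbonyl carbon remains open.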